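The source may hold more compounds than are shown below. What is called first, only, known or untested is meant among the compounds shown, and "the series" means these compounds.

In an ADME assay on Vero cells (Chlorocebus sabaeus) for cytotoxicity, read by MTT assay, with a stated time of 72 h (a lower number here means that less compound is tolerated, a higher number that more compound is tolerated), compound 1 (`O=C(N/N=C/c1ccccc1)c1ccc([N+](=O)[O-])o1`) offers no number, only the entry "not determined" (no result reported) for its result. Compound 2 (`O=C(N/N=C/c1ccccc1[N+](=O)[O-])c1ccc([N+](=O)[O-])o1`) gives 206000 nM, and this is the only figure available, so it cannot yet be ranked against any other compound. Compound 3 (`O=C(N/N=C/c1ccccc1C(F)(F)F)c1ccc([N+](=O)[O-])o1`) keeps the whole of compound 2 except for one group: it carries trifluoromethyl in place of nitro on an aromatic carbon, ortho to a large group (trifluoromethyl in place of nitro on an aromatic carbon). Going by the values given here, no pair of measured compounds shows what a change at this place does, so the expected size of the step in this assay is a judgement and not a reading from data. Since most of the structure stays the same, a modest change is expected, leaning towards a lower number and not far beyond the usual scatter. The estimated move is a 1.4-fold lower number from compound 2 to compound 3 (0.14 log units; within the scatter) and it starts from compound 2 at 206000 nM as the sole anchor. The expected value for compound 3 is 150000 nM, with an estimated range from 50000 nM to 400000 nM as its likely span.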

Compound 3, half-maximal cytotoxic concentration: > 191000 nM
Compound 3: only a limit was reported (the forecaster's own chance of this, stated with the estimate: 15%); at least 1.2-fold (0.10 log units) between middle value and limit.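

In this assay compound 3 gives > 191000 nM, which is a limit of the assay and not a number. Going by these compounds alone, no step from compound 2 to compound 3 can be read from this result: the limit of > 191000 nM in this assay, at which 1 of the 3 values shown sits. The compounds shown leave open how much trifluoromethyl in place of nitro changes the tolerated concentration, and where compound 1 stands.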